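The compounds below may be only part of what the source reports. "The series", "measured", "known", "first", "only" and "open" are said of these compounds alone.

Compound 1 `CN1CCN(c2ccc(/C=C3/SC(Nc4ccccc4)=NC3=O)cc2)CC1` gives 2500 nM in a functional assay on H460/TaxR cells (Homo sapiens) for cytotoxicity, read by sulforhodamine B assay, with a stated time of 48 h; a higher number here means that more compound is needed for the effect, a lower number that less compound is needed. Compound 2 `O=C1N=C(Nc2ccccc2)S/C1=C/c1ccc(N2CCNCC2)cc1` is obtained by hydrogen in place of methyl on an amine nitrogen in a ring. In this assay compound 2 gives only a limit, > 100000 nM. The step of an at least 40-fold higher number from compound 1 to compound 2 (1.60 log units; beyond the scatter) is large. Compound 3 `CN1CCN(c2ccc(/C=C3/SC(N(C)c4ccccc4)=NC3=O)cc2)CC1` differs from compound 1 by methyl in place of hydrogen on a nitrogen on an aromatic ring. In this assay compound 3 likewise gives only a limit, > 100000 nM. The step of an at least 40-fold higher number from compound 1 to compound 3 (1.60 log units; beyond the scatter) is also large, both of these values sitting at the limit of > 100000 nM in this assay, at which 2 of the 3 values shown sit. Compound 4 `CN(C1=NC(=O)/C(=C\c2ccc(N3CCNCC3)cc2)S1)c1ccccc1` is not yet measured; it differs from compound 3 by hydrogen in place of methyl on an amine nitrogen in a ring, the same change as from compound 1 to compound 2, with the place worded identically. The two cores differ by the change already told from compound 1 to compound 3. That change on its own produced an at least 40-fold higher number from compound 1 to compound 2 (1.60 log units; beyond the scatter) from a measurable start. Compound 3 begins at a limit. Compound 4 is therefore expected to stay at a limit, the expected step that the limit leaves unreadable from compound 3 to compound 4 being small. The estimate for compound 4 is 200000 nM, with a range from 100000 nM to 1000000 nM.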

Compound 4, half-maximal effective concentration: > 100000 nM
Compound 4 was reported as a limit; the forecaster's own chance of this, stated with the estimate: 90%; the middle value lies beyond the limit too.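

Among the compounds shown here, no step among compound 2, compound 3 and compound 4 can be read in this assay, as all three sit at one value: the limit of > 100000 nM in this assay, at which 3 of the 4 values shown sit. The compounds shown leave open whether 4-methylpiperazin-1-yl to piperazin-1-yl changes anything on the core of compound 3.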